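The source may report more compounds than this note shows. Statements on the series, on what has been measured and on what is new or still open speak of the compounds shown alone.

Measured in an ADME assay (liver) for metabolic stability, with Liver microsome (Rattus norvegicus) as the target, using microsomes; on this read-out lower numbers stand for slow clearance and higher numbers for fast clearance:
- compound 1 `CN(C(=O)c1csc(-c2cccnc2)n1)c1ccc(OCc2ccc3ccccc3n2)cc1`: > 283 mL/min/kg (a limit)
- compound 2 `CN(C(=O)c1ccc2ncsc2c1)c1ccc(OCc2ccc3ccccc3c2)cc1`: 48.3 mL/min/kg
- compound 3 `CN(C(=O)c1csc(-c2cccnc2)n1)c1ccc(OCc2ccc3ccccc3c2)cc1`: > 283 mL/min/kg (a limit)

Compound 3 gives > 283 mL/min/kg, which is a limit and not a number. Its place in the series is the limit of > 283 mL/min/kg in this assay, at which 2 of the 3 values shown sit.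

Compound 4 `CN(C(=O)c1ccncc1)c1ccc(OCc2ccc3ccccc3c2)cc1` has pyridin-4-yl in place of 2-(pyridin-3-yl)-1,3-thiazol-4-yl on a carbonyl carbon.

Two measured steps are at hand. The first, a step that the two limits leave unreadable from compound 1 to compound 3, concerns another part of the molecule and gives no size. The second changes the same carbonyl substituent, and 2-(pyridin-3-yl)-1,3-thiazol-4-yl entering in place of 1,3-benzothiazol-6-yl gave an at least 5.8-fold higher number from compound 2 to compound 3 (0.76 log units; beyond the scatter). On that step, the departure of the same group from compound 3 is expected to lower the number in this assay, though pyridin-4-yl itself has not been measured in this series. The expected change is an at least 3.1-fold lower number from compound 3 to compound 4 (0.49 log units; beyond the scatter). For compound 4 the estimated value is 90 mL/min/kg, with an expected range of 30 mL/min/kg to 270 mL/min/kg.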

Compound 4, clearance: 75 mL/min/kg
Estimate against measurement, compound 4: 1.2-fold (0.08 log units) above, within the range that was stated.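

In this assay compound 3 is a limit and not a number: the limit of > 283 mL/min/kg in this assay, at which 2 of the 4 values shown sit.

From that limit, the change on the carbonyl carbon gives an at least 3.7-fold lower number from compound 3 to compound 4 (0.57 log units; beyond the scatter), so only a lower bound on the size of the step can be read. With 1,3-benzothiazol-6-yl and now pyridin-4-yl, two different groups in place of 2-(pyridin-3-yl)-1,3-thiazol-4-yl come with lower numbers, and the step between them, a 1.6-fold higher number from compound 2 to compound 4 (0.19 log units; within the scatter), does not separate them.

The compounds shown leave open how a plain 1,3-thiazol-4-yl without the pyridin-3-yl, or a saturated amine such as piperidin-4-yl, would read on the carbonyl carbon. Also open, as far as these compounds go, is whether quinolin-2-yl in place of naphthalen-2-yl changes the read-out once the carbonyl substituent is pyridin-4-yl.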